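The source may hold more compounds than are shown below. What is called first, only, known or untested is meant among the compounds shown, and "the series" means these compounds.

Compound 1 `CC(C)C[C@H](N)c1cc(C(F)(F)F)ccc1N1CCN(C(=O)CC(C)C(=O)c2ccc(Cl)cc2)CC1` gives 1100 nM in an assay on HEK293 cells for displacement of a labelled ligand from Melanocortin receptor 4 (Homo sapiens); on this read-out lower numbers stand for stronger inhibition and higher numbers for weaker inhibition.
Compound 2 `CC(C)C[C@H](N)c1cc(C(F)(F)F)ccc1N1CCN(C(=O)C(C)Cc2ccc(Cl)cc2O)CC1` gives 36 nM in this assay.
Compound 3 `CC(C)C[C@H](N)c1cc(C(F)(F)F)ccc1N1CCN(C(=O)COc2ccc([N+](=O)[O-])cc2)CC1` gives 3100 nM in this assay.

Compound 3 stands at the highest of the three numbers. Its nearest neighbour is compound 1, separated by a 2.8-fold higher number from compound 1 to compound 3 (0.45 log units; beyond the scatter), and its furthest is compound 2, separated by an 86-fold higher number from compound 2 to compound 3 (1.94 log units; beyond the scatter). Compound 4 `CC(C)C[C@H](N)c1cc(C(F)(F)F)ccc1N1CCN(C(=O)CCC2CCCCC2)CC1` is not yet measured. It differs from compound 3 by cyclohexylmethyl in place of 4-nitrophenoxy on a saturated chain carbon bound to a carbonyl carbon.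

Within the data shown here, two measured steps bear on the amide side chain that changes here. Among the measured compounds shown here, the step of a 2.8-fold higher number from compound 1 to compound 3 (0.45 log units; beyond the scatter) is modest, and the step of an 86-fold higher number from compound 2 to compound 3 (1.94 log units; beyond the scatter) is large; both show that the side chain on the carbonyl carbon can move the number widely, but no measured compound carries a group without aromatic ring or acceptors, so the direction for compound 4 cannot be read from a close precedent. The chain in compound 4 resembles neither the hydroxybenzyl group of compound 2 nor the phenoxy group of compound 3. The expectation for compound 4 is therefore a step of a 2.1-fold lower number from compound 3 to compound 4 (0.32 log units; beyond the scatter), with wide uncertainty. Compound 4 is estimated at 1500 nM in this assay, within a range from 300 nM to 8000 nM.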

Compound 4, inhibition constant: 5700 nM
Compound 4: middle estimate off by 3.8-fold (0.58 log units), on the low side; measured number inside the range.
By their numbers in this assay, from the lowest: compound 2; then compound 1; then compounds 3 and 4 (each within the scatter of the next).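

In this assay, the exchange of 4-nitrophenoxy for cyclohexylmethyl on a saturated chain carbon bound to a carbonyl carbon leaves the two compounds within the usual scatter (a 1.8-fold higher number from compound 3 to compound 4 (0.26 log units; within the scatter)). At this position, then, a side chain with an aromatic ring and hydrogen-bond acceptors and one with a non-aromatic carbon ring and no acceptors cannot be told apart by their numbers, and this pair gives no sign that the aromatic ring or the acceptors of 4-nitrophenoxy matter here. The 2-cyclohexylethyl chain also stays far from the 1-(4-chloro-2-hydroxybenzyl)ethyl group (a 160-fold higher number from compound 2 to compound 4 (2.20 log units; beyond the scatter)) and clearly separated from the side chain of compound 1 (a 5.2-fold higher number from compound 1 to compound 4 (0.71 log units; beyond the scatter)), but no accompanying measurement explains either gap.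

The compounds shown leave open whether a plain 4-chlorobenzyl group, without the hydroxyl, would keep a number close to that of compound 2 (36 nM). They also leave open how an amine or a carboxylic acid on the chain, or a chain longer than 2-cyclohexylethyl, would read in this assay.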